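Swapping the fluorophenyl for a trifluoromethylphenyl on the shared core

The source may report more compounds than this note shows. Statements on the series, on what has been measured and on what is new or still open speak of the compounds shown alone.

Three compounds share one core and differ only in the aromatic group on it. Compound 1 `Fc1ccc(-c2cn3ccnc3c(-c3ccc4ncn(C5CCCCC5)c4c3)n2)cc1` gives 18% in a functional assay on HCT-116 cells (Homo sapiens) for inhibition, read by sulforhodamine B assay, with a stated time of 48 h, tested at 10 uM; on this read-out lower numbers stand for less inhibition and higher numbers for more inhibition at the one concentration tested (going by the name of the read-out). Compound 2 `c1cn2cc(-c3ccsc3)nc(-c3ccc4ncn(C5CCCCC5)c4c3)c2n1` gives 13.4% in this assay, and compound 3 `Fc1ccccc1-c1cn2ccnc2c(-c2ccc3ncn(C4CCCCC4)c3c2)n1` gives 25.8%. Within the data shown here, compound 3 therefore has the highest of the three numbers, but the gap to compound 1 is within the scatter, and only the step of a number 12.4 percentage points higher from compound 2 to compound 3 (beyond the scatter) stands beyond it. The step of a number 7.8 percentage points higher from compound 1 to compound 3 (within the scatter) shows that moving the fluorine around the ring hardly changes the read-out.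

Compound 4 `FC(F)(F)c1cccc(-c2cn3ccnc3c(-c3ccc4ncn(C5CCCCC5)c4c3)n2)c1` is not yet measured. Its change from compound 3 is 3-(trifluoromethyl)phenyl in place of 2-fluorophenyl on an aromatic carbon. Among the measured compounds shown here, no measured step trades one phenyl group for another carrying a trifluoromethyl, so the closest guides are the small step from compound 1 to compound 3 and the modest one from compound 2 to compound 3, both pointing to shifts near the scatter. The expected step is a number 3.8 percentage points lower from compound 3 to compound 4 (within the scatter), no clear direction. Compound 4 is thus estimated at 22%, within 8% to 40%.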

Compound 4, a percentage reported as inhibition, at one concentration (the size of the read-out at that concentration, not a potency): 17.6%
The estimate for compound 4 lay 4.4 percentage points above the measured number, within the range that was stated.
By their numbers in this assay, from the lowest: compounds 2, 4, 1 and 3 (each within the scatter of the next, the first and the last beyond it).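

In this assay, the position on the shared core accepts 3-(trifluoromethyl)phenyl, a group with more heavy atoms than any earlier one, without a step beyond the scatter against any earlier compound (a number 8.2 percentage points lower from compound 3 to compound 4 (within the scatter); a number 4.2 percentage points higher from compound 2 to compound 4 (within the scatter); a number 0.4 percentage points lower from compound 1 to compound 4 (within the scatter)). Compound 4 therefore does not separate from the other compounds, and the gap between compound 2 and compound 3 remains the only one beyond the scatter, so this larger group adds no clear change at this position. No measured information explains why these groups give such similar numbers.

Every group shown here is an aromatic ring, so it remains open how an amine, a carboxylic acid or a longer alkyl chain would read at this position. Going by these compounds, it is also open whether 4-(trifluoromethyl)phenyl would give a number like that of compound 4.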